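A smaller piperazine on a chemokine receptor agonist scaffold

This account rests on a few compounds, and the source may have more. Where it says the series, first, only, none or still open, it means among the compounds named here.

Compound 2 `CN(C[C@H]1Cc2c(cccc2N2CCN3CCC[C@@H]3C2)CN1)[C@H]1CCCc2cccnc21` reaches only a limit of the assay in a functional assay on CCRF-CEM cells for agonist activity at C-X-C chemokine receptor type 4 (Homo sapiens), read by calcium flux, with a stated time of 25 min (on this read-out higher numbers stand for an effect only at larger amounts of compound and lower numbers for an effect already at smaller amounts), giving > 30000 nM. Compound 1 `CN(C[C@H]1Cc2c(cccc2N2CCN(C3COC3)CC2)CN1)[C@H]1CCCc2cccnc21` likewise gives only a limit, > 30000 nM. The step that the two limits leave unreadable from compound 1 to compound 2 therefore cannot be read, and the limit of > 30000 nM in this assay, at which 2 of the 2 values shown sit, is all that the two values show. Compound 3 `CN1CCN(c2cccc3c2C[C@H](CN(C)[C@H]2CCCc4cccnc42)NC3)CC1` carries a group of 7 heavy atoms (5 carbon, 2 nitrogen; one six-membered non-aromatic ring with 2 hetero atoms) in place of a group of 9 heavy atoms (7 carbon, 2 nitrogen; one five-membered non-aromatic ring with 1 hetero atom, one six-membered non-aromatic ring with 2 hetero atoms), on an aromatic carbon. Among the measured compounds shown here, no measured step bears readably on this change, so the step that the limit leaves unreadable from compound 2 to compound 3 is expected to be unreadable as well, and compound 3 is expected to return another limit rather than a number. The estimate for compound 3 is 35000 nM, between 8000 nM and 150000 nM.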

Compound 3, half-maximal effective concentration: > 30000 nM
Compound 3 was reported as a limit; the forecaster's own chance of this, stated with the estimate: 85%; the middle value does not contradict the limit.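

Compound 3, like compound 1 and compound 2, gives only a limit in this assay, so no step among them can be read: the limit of > 30000 nM in this assay, at which 3 of the 3 values shown sit.

The compounds shown leave open how their three groups on the aromatic carbon rank in this assay, and whether any group there would give a readable number.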